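The compounds below may be only part of what the source reports. "The series", "measured", "known", "first", "only" and "open" are said of these compounds alone.

In an ADME assay on HFF cells (Homo sapiens) for cytotoxicity, with a stated time of 8 days (on this read-out lower numbers stand for higher toxicity in this test and higher numbers for lower toxicity in this test), compound 1 (`CNc1nc(N)nc2c1ncn2/C=C1/CC1(CO)CO`) gives 265000 nM as a measured number. Compound 2 (`CCCCCCCCOc1nc(N)nc2c1ncn2/C=C1/CC1(CO)CO`) gives > 300000 nM and this is a limit of the assay, not a number. Compound 3 (`Nc1nc(N2CCCC2)c2ncn(/C=C3/CC3(CO)CO)c2n1`) gives > 300000 nM and this too is only a limit. Compound 3 therefore stands at the limit of > 300000 nM in this assay, at which 2 of the 3 values shown sit, and has no exact value of its own.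

The next step leads to compound 4 (`Nc1nc(NC2CCCC2)c2ncn(/C=C3/CC3(CO)CO)c2n1`), where cyclopentylamino takes the place of pyrrolidin-1-yl on an aromatic carbon of the shared core: cyclopentylamino in place of pyrrolidin-1-yl on an aromatic carbon. Two measured steps change the group at this same carbon. One is an at least 1.1-fold higher number from compound 1 to compound 3 (0.05 log units; that floor lies within the scatter) with pyrrolidin-1-yl in place of methylamino. The other is an at least 1.1-fold higher number from compound 1 to compound 2 (0.05 log units; that floor lies within the scatter) with octyloxy in place of methylamino. Neither shows a change beyond the scatter, and the third step, a step that the two limits leave unreadable from compound 2 to compound 3, cannot be sized. With such different groups giving so little separation, no clear shift is expected for the new group in this assay. The expected change is an at least 1.1-fold lower number from compound 3 to compound 4 (0.06 log units; that floor lies within the scatter) which means no step beyond the scatter. For compound 4 the estimated value is 260000 nM with an expected range from 100000 nM to 300000 nM in this test, and a report of only a limit would be no surprise.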

Compound 4, half-maximal cytotoxic concentration: > 300000 nM
Compound 4: only a limit was reported; the forecaster's own chance of this, stated with the estimate: 55%; at least 1.1-fold (0.06 log units) between middle value and limit.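

In this assay, compound 4 shows that a group with a hydrogen-bond donor on the attached nitrogen, which pyrrolidin-1-yl lacks, also gives only a limit at this carbon. Among these compounds, the one step that can be read is an at least 1.1-fold higher number from compound 1 to compound 4 (0.05 log units; that floor lies within the scatter), so swapping the methyl on that nitrogen for cyclopentyl shows no change beyond the scatter. Both ends of the steps to compound 4 from compound 2 and compound 3 are limits, so neither step can be read, and most of the series now sits at one limit: the limit of > 300000 nM in this assay, at which 3 of the 4 values shown sit.

With so few exact numbers, the compounds shown cannot rank these groups against one another, and a real difference among them could lie hidden past the limit. From the compounds shown here alone, it also remains open whether a carboxylic acid or a piperidine ring at this carbon would give an exact number in this test.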